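The source may report more compounds than this note shows. Statements on the series, on what has been measured and on what is new or still open speak of the compounds shown alone.

Compounds measured so far:
compound 1, `O=C1/C(=C/c2ccc(F)cc2)CCC/C1=C\c1cccc([N+](=O)[O-])c1`, 5.06
compound 2, `COc1ccc(/C=C2\CCC/C(=C\c3ccccc3[N+](=O)[O-])C2=O)cc1`, 4.86
compound 3, `COc1ccc(/C=C2\CCC/C(=C\c3cccc([N+](=O)[O-])c3)C2=O)cc1`, 5.06

In a physicochemical assay for lipophilicity (a lower number here means a more polar compound, a higher number a more lipophilic compound), compound 2 stands lowest of the three numbers, but its gap to compound 1 and its gap to compound 3 both lie within the scatter, so no order among the three can be read from them. Going by the values given here, the only step between measured compounds that changes one place is no change at the digits printed from compound 1 to compound 3 (within the scatter), methoxy in place of fluoro on an aromatic carbon.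

Compound 4, `O=C1/C(=C/c2ccc(Cl)cc2)CCC/C1=C\c1ccccc1[N+](=O)[O-]`, differs from compound 2 in one place: chloro in place of methoxy on an aromatic carbon. Among the compounds with values here, no measured pair in this set exchanges methoxy for chloro, so the step from compound 1 to compound 3 is the nearest comparison, and it showed no change beyond the scatter. Compound 4 is therefore expected to sit near compound 2, with at most a modest shift upward, a number 0.44 log units higher from compound 2 to compound 4 (beyond the scatter). For compound 4 the estimate in this assay is 5.3, with a range from 4.9 to 5.7.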

Compound 4, partition coefficient: 4.86
For compound 4 the middle estimate is 0.44 log units above the measured one; measured number below the stated range.
By their numbers in this assay, from the lowest: compounds 2, 4, 1 and 3 (each within the scatter of the next).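

In this assay, chloro in place of methoxy on this aromatic carbon, para to a large group, gives no change at the digits printed from compound 2 to compound 4 (within the scatter) and so adds a second exchange at this place. The earlier exchange, methoxy in place of fluoro, gives no change at the digits printed from compound 1 to compound 3 (within the scatter) on a different background, so both exchanges shown here at this place stay within the scatter, and neither pair goes against that reading, though two pairs establish no general rule. No measured evidence is available to account for this result.

From the compounds shown here alone, whether an amine, a carboxylic acid or a longer chain on this aromatic carbon would stay within the scatter remains open. No exchange shown at this place gives a step beyond the scatter, so the size of change this position can carry in this assay is still unknown.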